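Swapping a Sulfur-Bearing Chain End for Dimethylamino

This account rests on a few compounds, and the source may have more. Where it says the series, first, only, none or still open, it means among the compounds named here.

Compound 1 `CNS(=O)(=O)CCn1c(=N)sc2cc(OC(F)(F)F)ccc21`: 4 mg/kg
Compound 2 `C[S+]([O-])CCn1c(=N)sc2cc(OC(F)(F)F)ccc21`: 1.1 mg/kg
Compound 3 `C[S+]([O-])CCCn1c(=N)sc2cc(OC(F)(F)F)ccc21`: 2.3 mg/kg

In a functional assay on the whole organism with Rattus norvegicus as the target (on this read-out lower numbers stand for an effect already at smaller amounts and higher numbers for an effect only at larger amounts of compound), compound 3 gives 2.3 mg/kg. It lies within the scatter on one side, a 1.7-fold lower number from compound 1 to compound 3 (0.24 log units; within the scatter), and just clear of it on the other, a 2.1-fold higher number from compound 2 to compound 3 (0.32 log units; beyond the scatter).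

Compound 4 `CN(C)CCn1c(=N)sc2cc(OC(F)(F)F)ccc21` differs from it by a group of 3 heavy atoms (2 carbon, 1 nitrogen; no ring) in place of a group of 4 heavy atoms (2 carbon, 1 oxygen, 1 sulfur; no ring), on a saturated chain carbon, two bonds along the chain from an aromatic nitrogen. Going by the values given here, no measured compound carries dimethylamino, so the only guide is the size of the other swaps at this place. The largest of these is a 3.6-fold lower number from compound 1 to compound 2 (0.56 log units; beyond the scatter), which is modest. A modest step at most is therefore expected, in no firmly known direction. The expected outcome is a 1.3-fold higher number from compound 3 to compound 4 (0.12 log units; within the scatter), with no step beyond the scatter foreseen. Compound 4 is estimated at 3 mg/kg, with an expected range of 1 mg/kg to 9 mg/kg.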

Compound 4, dose for half-maximal effect: 2.3 mg/kg
Compound 4: middle estimate off by 1.3-fold (0.12 log units), on the high side, within the range that was stated.
By their numbers in this assay, from the lowest: compound 2; then compounds 3, 4 and 1 (each within the scatter of the next).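

Going by these compounds alone, in (this assay), dimethylamino, the first group here without sulfur, stays within the scatter of two sulfur-bearing chain ends (no change at the digits printed from compound 3 to compound 4 (within the scatter); a 1.7-fold lower number from compound 1 to compound 4 (0.24 log units; within the scatter)), while the gap to the third is modest but beyond the scatter (a 2.1-fold higher number from compound 2 to compound 4 (0.32 log units; beyond the scatter)). This place, on a saturated chain carbon, therefore accepts a group without sulfur, and compound 2 alone keeps the lowest number. No available evidence accounts for these steps. As far as these compounds go, whether a carboxylic acid, a morpholine ring or a longer chain ending in dimethylamino would stay in this range remains open.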